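Removing the ring methyl from compound 1: clearance expectation

This account rests on a few compounds, and the source may have more. Where it says the series, first, only, none or still open, it means among the compounds named here.

Compound 1 `CNC(=O)c1ccccc1-c1ccc(CNc2nccc(C)c2NC(=O)CC(F)(F)F)cc1` was measured in an in vivo ADME assay on the whole organism (Rattus norvegicus, strain Sprague Dawley) for pharmacokinetics (on this read-out lower numbers stand for slow clearance and higher numbers for fast clearance), where compound 1 gives 30 mL/min/kg. Among the three measured compounds it holds the second highest number; its nearest neighbour, compound 3 `CNC(=O)c1ccccc1-c1ccc([C@@H](C)Nc2nccc(C)c2NC(=O)CC(F)(F)F)cc1`, gives 31 mL/min/kg, and the only single-place step on record, a 1.0-fold higher number from compound 1 to compound 3 (0.01 log units; within the scatter), shows that adding methyl in place of hydrogen on a saturated chain carbon bound to an aromatic carbon and a nitrogen on an aromatic ring left the read-out unchanged. Compound 2 `COC(=O)c1ccccc1-c1ccc([C@@H](C)Nc2nccc(C)c2NC(=O)CC#N)cc1` differs from compound 1 at several points. In this assay compound 2 gives 18.5 mL/min/kg, a value within the scatter of compound 1.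

Compound 4 `CNC(=O)c1ccccc1-c1ccc(CNc2ncccc2NC(=O)CC(F)(F)F)cc1` differs from compound 1 only at one point: hydrogen in place of methyl on an aromatic carbon. The change sits on an aromatic carbon of a six-membered aromatic ring with one nitrogen, opposite the ring nitrogen. Going by the values given here, no measured step addresses this position, and the one measured step touching a methyl was within the scatter. Compound 4 is therefore expected to show no change at the digits printed from compound 1 to compound 4 (within the scatter), with an estimate of 30 mL/min/kg and a range from 15 mL/min/kg to 60 mL/min/kg.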

Compound 4, clearance: 15 mL/min/kg
For compound 4 the middle estimate is 2.0-fold (0.30 log units) above the measured one; the measured number falls inside the stated range.
By their numbers in this assay, from the lowest: compounds 4, 2, 1 and 3 (each within the scatter of the next, the first and the last beyond it).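

Compounds 1, 2 and 3 all carry the methyl on this aromatic carbon, opposite the ring nitrogen, so they gave no reading of the position itself. In this assay, hydrogen in place of that methyl gives a 2.0-fold lower number from compound 1 to compound 4 (0.30 log units; within the scatter), which shows that, on the core of compound 1, this methyl can be lost without a step beyond the scatter. Nothing available bears on why the read-out of compound 4 stands where it does.

From the compounds shown here alone, whether another group on this carbon, such as an amine, a methoxy group or a chlorine atom, would give a step beyond the scatter remains open. Also open, going by these compounds, is whether the same change would read alike in the presence of the added chain methyl of compound 3 or the methyl ester and nitrile of compound 2.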